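The compounds below may be only part of what the source reports. "The series", "measured", "known", "first", "only" and "open" are said of these compounds alone.

Measured so far in a functional assay on MCF7 cells (Homo sapiens) for antiproliferative activity, with a stated time of 72 h; a higher number here means a weaker inhibitor, a lower number a stronger inhibitor:
- compound 1, `COc1ccc(C2CC(c3ccccc3)=NN2c2nc(-c3ccccc3)c(C#N)c(=O)n2C)cc1`: 18000 nM
- compound 2, `COc1ccc(C2CC(c3ccc(Cl)cc3)=NN2c2nc(-c3ccccc3)c(C#N)c(=O)n2C)cc1`: 4800 nM

Going by the values given here, compound 2 stands at the lower of the two numbers in this assay; its nearest neighbour is compound 1, and the step of a 3.8-fold lower number from compound 1 to compound 2 (0.57 log units; beyond the scatter) is the only one recorded so far.

The next compound, compound 3 `COc1ccc(C2=NN(c3nc(-c4ccccc4)c(C#N)c(=O)n3C)C(c3ccc(OC)cc3)C2)cc1`, differs from compound 2 by methoxy in place of chloro on an aromatic carbon. Among the compounds with values here, no recorded step replaces a chloro group with a methoxy group, so the bearing of the known data is indirect. Within the data shown here, the single step, chloro entering in place of hydrogen, moved the number down by a modest amount. Methoxy is a different substituent at the same place, and nothing in the series shows how it compares with either hydrogen or chloro there. The safest reading is that compound 3 lands between compound 1 and compound 2, closer to compound 2, with a wide range on either side.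

The expected step is a 1.7-fold higher number from compound 2 to compound 3 (0.22 log units; within the scatter). For compound 3 the estimated value in this assay is 8000 nM, with a likely range from 3000 nM to 25000 nM.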

Compound 3, half-maximal inhibitory concentration: 127000 nM
Estimate against measurement, compound 3: 16-fold (1.20 log units) below, and the stated range ends below it.
By their numbers in this assay, from the lowest: compound 2; then compound 1; then compound 3.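

In this assay, going by these compounds alone, the substituent on this aromatic carbon matters far more than the one earlier step suggested: methoxy in place of chloro gives a 26-fold higher number from compound 2 to compound 3 (1.42 log units; beyond the scatter), and methoxy in place of hydrogen gives a 7.1-fold higher number from compound 1 to compound 3 (0.85 log units; beyond the scatter). The second of these runs opposite to the earlier chloro step (a 3.8-fold lower number from compound 1 to compound 2 (0.57 log units; beyond the scatter)), so replacing hydrogen at this place does not in itself lower the number, and the direction depends on which group enters. Nothing on hand explains why chloro and methoxy part so widely here.

Still open, on these data alone, is whether the rise belongs to methoxy alone or extends to other groups at this carbon, such as fluoro, hydroxy, an amine or a longer chain like ethoxy. Also open, as far as these compounds go, is whether chloro would lower the number to a similar extent if the other substituents on the shared core were changed, since all three compounds vary in this one place only.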